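Thiophen-2-yl Replacing Pyridin-3-yl on the Shared Core

The compounds below may be only part of what the source reports. "The series", "measured", "known", "first", "only" and "open" are said of these compounds alone.

Measured compounds:
- compound 1 `O=C(Nc1ccc(-c2cscn2)cc1)C1CCCN(S(=O)(=O)c2ccc(F)c(F)c2)C1` gives > 20000 nM in a functional assay on A-375 cells (Homo sapiens) for antiproliferative activity (on this read-out higher numbers stand for weaker inhibition and lower numbers for stronger inhibition), which is a limit of the assay and not a number.
- compound 2 `O=C(Nc1ccc(-c2cccnc2)cc1)C1CCCN(Cc2ccc(F)c(F)c2)C1` gives 610 nM in this assay.

Compound 2 thus stands as the only actual number shown; the other value is a limit (the limit of > 20000 nM in this assay, at which 1 of the 2 values shown sits). Compound 3 `O=C(Nc1ccc(-c2cccs2)cc1)C1CCCN(Cc2ccc(F)c(F)c2)C1` differs from compound 2 in one place: thiophen-2-yl in place of pyridin-3-yl on an aromatic carbon. Within the data shown here, no measured step between compounds differing in one place is available, so the size of this change in this assay is uncertain; a step no larger than the usual scatter is expected, a 1.3-fold higher number from compound 2 to compound 3 (0.12 log units; within the scatter). Compound 3 is therefore estimated at 800 nM, with a range from 250 nM to 2500 nM.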

Compound 3, half-maximal inhibitory concentration: 390 nM
For compound 3 the middle estimate is 2.1-fold (0.31 log units) above the measured one; low and high end bracket the measured number.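

In this assay, thiophen-2-yl in place of pyridin-3-yl gives a 1.6-fold lower number from compound 2 to compound 3 (0.19 log units; within the scatter), so the two rings cannot be told apart on this read-out. On this aromatic carbon, para to a large group, a five-membered ring with sulfur therefore serves as well as a six-membered ring with nitrogen, and the pyridine nitrogen is not needed to keep this level of activity on this core. On these data alone, whether a plain phenyl ring, a morpholine or a carboxylic acid at this position would also hold that level remains open. Nothing measured here speaks to why these two rings read alike.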